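Cytotoxicity notes on an azidomethyl analogue of compound 2

The source may report more compounds than this note shows. Statements on the series, on what has been measured and on what is new or still open speak of the compounds shown alone.

Of the compounds shown here, two of the shared core have been measured in an ADME assay on Huh-5-2 cells (Homo sapiens) for cytotoxicity, with a stated time of 3 days; a higher number here means that more compound is tolerated, a lower number that less compound is tolerated. Compound 1 `COC[C@H]1C[C@@](CC(C)C)(C(=O)O)N(C(=O)c2ccc(C(C)(C)C)c(OC)c2)[C@@H]1c1nccs1` gives 200000 nM. Compound 2 `COC[C@H]1C[C@@](CC(C)C)(C(=O)O)N(C(=O)c2ccc(C(C)(C)C)c(OC)c2)[C@H]1C(=O)OC` carries a methoxycarbonyl on the saturated ring carbon. In this assay compound 2 reports > 120000 nM, which is a limit of the assay and not a number. This is the limit of > 120000 nM in this assay, at which 1 of the 2 values shown sits. The numbers shown thus do not separate compound 2 from compound 1.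

Compound 3 `COC[C@H]1C[C@@](CC(C)C)(C(=O)O)N(C(=O)c2ccc(C(C)(C)C)c(OC)c2)[C@H]1CN=[N+]=[N-]` differs from compound 2 in one place: azidomethyl in place of methoxycarbonyl on a saturated ring carbon. Going by the values given here, no measured step of this kind is available among the compounds here. The expected step is a step that the limit leaves unreadable from compound 2 to compound 3, which means no change beyond the scatter in either direction. For compound 3 the estimate in this assay is 150000 nM, with a range from 50000 nM to 300000 nM.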

Compound 3, half-maximal cytotoxic concentration: > 120000 nM
Compound 3: only a limit was reported; the forecaster's own chance of this, stated with the estimate: 50%; the middle value does not contradict the limit.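

In this assay compound 3 gives > 120000 nM as a limit of the assay and not a number. Going by these compounds alone, with compound 2 also at a limit, no step from compound 2 to compound 3 can be read: the limit of > 120000 nM in this assay, at which 2 of the 3 values shown sit. Left open is whether azidomethyl in place of methoxycarbonyl on a saturated ring carbon changes the tolerated concentration at all.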